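Swapping a Hydroxymethylphenyl for a Pyridinyl on a Furan Acid

This account rests on a few compounds, and the source may have more. Where it says the series, first, only, none or still open, it means among the compounds named here.

The starting point is compound 1, `Cc1oc(C(=O)O)cc1COc1ccc(-c2ccc(CO)cc2)cc1`. Among the compounds with values here, in an assay on cells for displacement of a labelled ligand from prostaglandin E2 receptor EP4 subtype (Homo sapiens), read by scintillation counting (a lower number here means a stronger inhibitor, a higher number a weaker inhibitor), compound 1 gives 3000 nM, the higher of the two numbers measured so far. Within the data shown here, the only other measured compound, compound 2, `COc1ccc(-c2ccc(OCc3cc(C(=O)NS(=O)(=O)Cc4ccccc4)oc3C)cc2)cc1`, gives 3 nM in this assay. The gap between compound 1 and compound 2 lies far beyond the usual scatter, yet the two structures differ in several places at once, so no single step can be read off from that pair.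

Compound 3, `Cc1oc(C(=O)O)cc1COc1ccc(-c2ccncc2)cc1`, keeps the core of compound 1 and changes one group: pyridin-4-yl in place of 4-(hydroxymethyl)phenyl on an aromatic carbon. Among the measured compounds shown here, no measured pair shows what this exchange does on its own. The acid and the rest of the core remain as they are in compound 1, the compound with the higher number, so nothing measured points toward a large gain. The expected step from compound 1 to compound 3 is a 1.7-fold higher number from compound 1 to compound 3 (0.22 log units; within the scatter), a modest shift toward weaker inhibition that may still fall within the scatter. Compound 3 is therefore estimated to give 5000 nM in this assay, with a range from 1000 nM to 30000 nM.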

Compound 3, inhibition constant: > 10000 nM
Compound 3: no number, only a limit (the forecaster's own chance of this, stated with the estimate: 20%); middle value at least 2.0-fold (0.30 log units) away from the limit.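

In this assay compound 3 gives > 10000 nM, which is a limit of the assay and not a number. Even so, the exchange of 4-(hydroxymethyl)phenyl for pyridin-4-yl can be read as a single change, something the pair of compound 1 and compound 2 could not offer: it gives an at least 3.3-fold higher number from compound 1 to compound 3 (0.52 log units; beyond the scatter), so the group at this place, para to a large group, does matter on this acid-bearing core, and this exchange moves the number toward weaker inhibition. Only the minimum size of that step is known, and its true size stays hidden because the reading for compound 3 is a limit: the limit of > 10000 nM in this assay, at which 1 of the 3 values shown sits.

In this one step the hydroxymethyl group leaves and the ring nitrogen enters together, and the compounds shown do not separate the two. Also open, from the compounds shown here alone, is how a plain phenyl or a 4-(aminomethyl)phenyl at this place would read in this assay, which would show whether the hydroxymethyl group itself contributes to the number of compound 1.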